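Fluoro-to-hydrogen step on the central aryl ether ring

This account rests on a few compounds, and the source may have more. Where it says the series, first, only, none or still open, it means among the compounds named here.

Four compounds share a core; the difference between the core of compound 1 `CNC(=O)c1cc(Oc2ccc(NC(=O)c3cc(-c4ccc(Cl)cc4)ncn3)cc2F)ccn1` and the core of compound 3 `CNC(=O)c1cc(Oc2ccc(NC(=O)c3nccc(-c4ccc(OC)cc4)n3)cc2F)ccn1` is not broken down here. In a functional assay on A549 cells (Homo sapiens) for cytotoxicity, read by MTT assay, with a stated time of 72 h (a lower number here means a stronger inhibitor, a higher number a weaker inhibitor), compound 1 gives > 100000 nM, which is a limit of the assay rather than a number. Compound 2 `CNC(=O)c1cc(Oc2ccc(NC(=O)c3cc(-c4ccc(Cl)cc4)ncn3)cc2)ccn1` is compound 1 after (hydrogen in place of fluoro on an aromatic carbon). In this assay compound 2 gives > 100000 nM, again a limit of the assay and not a number. The change from compound 1 to compound 2 is therefore a step that the two limits leave unreadable from compound 1 to compound 2, the reason being (the limit of > 100000 nM in this assay, at which 2 of the 3 values shown sit).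

For the measured compounds named here, compound 3 is the only member of the set with a number in this assay, where compound 3 gives 16600 nM. Going by the values given here, compound 4 `CNC(=O)c1cc(Oc2ccc(NC(=O)c3nccc(-c4ccc(OC)cc4)n3)cc2)ccn1` is compound 3 after (hydrogen in place of fluoro on an aromatic carbon), the same change as the one between compound 1 and compound 2, at the same place.

Since the measured pair gives no readable size for this change, the expectation for compound 4 rests on compound 3 alone, whose value of 16600 nM is taken as the anchor, with the step from compound 3 to compound 4 expected to be a 1.2-fold higher number from compound 3 to compound 4 (0.08 log units; within the scatter). On that basis compound 4 is estimated at 20000 nM in this assay, expected to fall between 6000 nM and 70000 nM.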

Compound 4, half-maximal inhibitory concentration: 11100 nM
Compound 4: middle estimate off by 1.8-fold (0.26 log units), on the high side, and the stated range covers the measured number.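

Hydrogen in place of fluoro on an aromatic carbon gives a 1.5-fold lower number from compound 3 to compound 4 (0.17 log units; within the scatter) in this assay, so on the core of compound 3 this change has no size that stands out from repeat measurements. Compound 1 and compound 2 both sit at a limit of the assay and not at numbers, so the same change on their core cannot be read: the limit of > 100000 nM in this assay, at which 2 of the 4 values shown sit. The series therefore holds one readable pair on one core, which shows neither that the change carries over to the core of compound 1 nor that it does not.

Open, from the compounds shown here alone, is whether a group other than fluoro or hydrogen at this aromatic carbon, such as an amine or a nitrile, would move the number in this assay beyond the scatter. Also open, going by these compounds, is whether the core of compound 1, with a further group such as a carboxylic acid on it, would come off the limit and give numbers from which the size of the change could be read on a second core.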